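This account rests on a few compounds, and the source may have more. Where it says the series, first, only, none or still open, it means among the compounds named here.

In a functional assay on K562 cells (Homo sapiens) for cytotoxicity, with a stated time of 72 h (a higher number here means a weaker inhibitor, a lower number a stronger inhibitor), compound 1 `CC(C)[C@H](NC(=O)c1cc(Cl)ccc1O)C(=O)Nc1ccc(Cl)cc1` gives > 20000 nM, which is a limit of the assay. In this assay compound 2 `CC(C)[C@H](NC(=O)c1ccc(Cl)cc1O)C(=O)Nc1ccc(Br)cc1` gives > 10000 nM, again a limit. In this assay compound 3 `CC(C)[C@H](NC(=O)c1ccc(Cl)cc1O)C(=O)Nc1ccc(Cl)c(Cl)c1` gives > 10000 nM, also a limit and not a number.

Compound 3 therefore stands only at a limit in this assay, as do the other two measured compounds; two of the three values sit at the limit of > 10000 nM in this assay, at which 2 of the 3 values shown sit, and one at the limit of > 20000 nM in this assay, at which 1 of the 3 values shown sits. For the measured compounds named here, the single step between compounds that differ in one place, a step that the two limits leave unreadable from compound 2 to compound 3, is unreadable because both ends are limits.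

Compound 4 `C[C@H](NC(=O)c1ccc(Cl)cc1O)C(=O)Nc1ccc(Cl)c(Cl)c1` differs from compound 3 by methyl in place of isopropyl on a saturated chain carbon bound to an amide-type nitrogen and a carbonyl carbon. Going by the values given here, no measured step touches this position, and the only measured step, from compound 2 to compound 3, gives no readable size. Nothing among the three measured compounds shows a change that lifts a value off the limit, so compound 4 is expected to behave like compound 3, with the step that the limit leaves unreadable from compound 3 to compound 4 estimated to be none beyond the scatter. Compound 4 is accordingly estimated at 15000 nM in this assay, in the range 5000 nM to 40000 nM, most likely reported again only as a limit.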

Compound 4, half-maximal inhibitory concentration: > 12500 nM
Compound 4 ended at the assay's limit (the forecaster's own chance of this, stated with the estimate: 85%); the middle value does not contradict the limit.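

In this assay compound 4 gives > 12500 nM, which is a limit of the assay and not a number. Compound 3 also stands only at a limit, so the step from compound 3 to compound 4 cannot be read. The compounds shown leave open whether any change in this series would bring a value off the limit in this assay.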